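The source may report more compounds than this note shows. Statements on the series, on what has been measured and on what is new or still open speak of the compounds shown alone.

Series notes. The shared core carries a saturated chain; compound 1 `CCCCCCc1nc(O)cc(O)n1` and compound 2 `CCCCCc1nc(O)cc(O)n1` differ only at the end of that chain. In a functional assay on HEK293 cells for agonist activity at G-protein coupled receptor 84 (Homo sapiens), read by calcium flux (a higher number here means a larger maximal response, a lower number a smaller maximal response), compound 1 gives 99.7%, and compound 2 gives 84.9%. Within the data shown here, the one measured step is a number 14.8 percentage points lower from compound 1 to compound 2 (beyond the scatter), hydrogen in place of methyl on a saturated chain carbon, five bonds along the chain from an aromatic carbon. Among the measured compounds shown here, compound 2 therefore stands lowest of the two numbers so far, with compound 1 as its nearest and higher neighbour.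

Compound 3 `CCCCCCCCc1nc(O)cc(O)n1` is not yet measured. Against compound 2 the change is propyl in place of hydrogen on a saturated chain carbon, five bonds along the chain from an aromatic carbon. For the measured compounds named here, the only step that bears on it is the one from compound 1 to compound 2, which shortened the chain at the same place and cost a modest amount; compound 3 lengthens it there, in the opposite direction and by more. The expectation is thus an upward step in this assay of a number 13.1 percentage points higher from compound 2 to compound 3 (beyond the scatter), beyond the scatter. Compound 3 is expected to reach 98%, estimated within 82% to 114%.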

Compound 3, largest response reached (reported as percent of maximum), in percent of the reference or control that the assay uses: 110%
For compound 3 the middle estimate is 12 percentage points below the measured one, and the stated range covers the measured number.
By their numbers in this assay, from the lowest: compound 2; then compound 1; then compound 3.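

Lengthening the chain on this saturated chain carbon, five bonds along the chain from an aromatic carbon, works as a change in its own right: propyl in place of hydrogen gives a number 25.1 percentage points higher from compound 2 to compound 3 (beyond the scatter) in this assay and so more than restores what the shorter chain lost. The response does not level off at compound 1, since ethyl in place of hydrogen, six bonds along the chain from an aromatic carbon, gives a number 10.3 percentage points higher from compound 1 to compound 3 (beyond the scatter) as a further rise. Among these three compounds the number rises with chain length and none goes against that order, while no supporting evidence bears on the reason for the rise.

On these data alone, whether a still longer chain extends this rise or reverses it remains open. So does the effect of a chain ending in a carboxylic acid or an amine at the same place.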